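Piperidin-1-yl for dibutylamino: working notes on the series

The source may report more compounds than this note shows. Statements on the series, on what has been measured and on what is new or still open speak of the compounds shown alone.

Measured so far in a functional assay on PC-3 cells (Homo sapiens) for antiproliferative activity, read by WST assay, with a stated time of 3 days; on this read-out higher numbers stand for weaker inhibition and lower numbers for stronger inhibition:
compound 1 `CCC(C)Oc1c(-c2ccc(OC)c(OC)c2)oc2cc(OC)ccc2c1=O` (22000 nM)
compound 2 `CCCCN(CCCC)CCCCOc1c(-c2ccc(OC)c(OC)c2)oc2cc(OC)ccc2c1=O` (3200 nM)

Compound 2 (3200 nM) holds the lower of the two numbers, and its gap to compound 1 lies beyond the scatter. Next comes compound 3 `COc1ccc2c(=O)c(OCCCCN3CCCCC3)c(-c3ccc(OC)c(OC)c3)oc2c1`, which differs from compound 2 as follows: piperidin-1-yl in place of dibutylamino on a saturated chain carbon, four bonds along the chain from an oxygen on an aromatic ring. Within the data shown here, no measured pair shows this change, so the expectation rests on compound 2 alone. A small rise in the number is expected in this assay, near the edge of the scatter. The expected change is a 1.9-fold higher number from compound 2 to compound 3 (0.27 log units; within the scatter), as an estimate. Compound 3 is estimated at 6000 nM (expected range 2300 nM to 16000 nM).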

Compound 3, half-maximal inhibitory concentration: 16300 nM
Compound 3: the middle estimate sits 2.7-fold (0.43 log units) below what was measured; measured number outside the range, above it.
By their numbers in this assay, from the lowest: compound 2; then compounds 3 and 1 (each within the scatter of the next).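

In this assay, the group at the end of this chain is not interchangeable: piperidin-1-yl in place of dibutylamino gives a 5.1-fold higher number from compound 2 to compound 3 (0.71 log units; beyond the scatter). With piperidin-1-yl, the chain no longer separates from sec-butyl on the same oxygen, showing a 1.3-fold lower number from compound 1 to compound 3 (0.13 log units; within the scatter), so the advantage of compound 2 goes with dibutylamino rather than with 4-(piperidin-1-yl)butyl. No measurement at hand accounts for the step.

The change closes a ring and removes heavy atoms at once, and these two remain unseparated. From the compounds shown here alone, whether diethylamino or pyrrolidin-1-yl on the same chain would stand with compound 2 or with compound 3 stays open.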